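Replacing benzyl(methyl)amino with (2-methoxybenzyl)amino in a sulfonamide series

This account rests on a few compounds, and the source may have more. Where it says the series, first, only, none or still open, it means among the compounds named here.

Three compounds share a bis(trifluoromethyl)phenyl sulfonamide core linked through a three-carbon chain to an amine. Within the data shown here, compound 1 `O=S(=O)(NCCCNCc1cccc2ccccc12)c1cc(C(F)(F)F)cc(C(F)(F)F)c1` gives 2700 nM in a functional assay on Capan-2 cells (Homo sapiens) for inhibition, read by MTT assay, with a stated time of 72 h (on this read-out lower numbers stand for stronger inhibition of growth and higher numbers for weaker inhibition of growth), and compound 2 `O=S(=O)(NCCCNCC1COc2ccccc2O1)c1cc(C(F)(F)F)cc(C(F)(F)F)c1` gives 2500 nM in this assay; the only step measured between single-point neighbours, a 1.1-fold lower number from compound 1 to compound 2 (0.03 log units; within the scatter), shows that exchanging one ring group for another at that position left the number essentially unchanged. Compound 3 `CN(CCCNS(=O)(=O)c1cc(C(F)(F)F)cc(C(F)(F)F)c1)Cc1ccccc1` stands apart at 46000 nM, the highest of the three numbers, with compound 1 its nearest neighbour and compound 2 its furthest.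

Compound 4 `COc1ccccc1CNCCCNS(=O)(=O)c1cc(C(F)(F)F)cc(C(F)(F)F)c1` is formed from compound 3 by (2-methoxybenzyl)amino in place of benzyl(methyl)amino on a saturated chain carbon, three bonds along the chain from a sulfonamide nitrogen. Among the measured compounds shown here, no measured step covers this exact change. For the measured compounds named here, compound 3 is the only measured compound carrying benzyl(methyl)amino, and it is also the only one far above the others, while compounds 1 and 2 with different amine substituents sit together near the low end. The expectation is therefore that compound 4 returns toward the region of compounds 1 and 2, a step of a 12-fold lower number from compound 3 to compound 4 (1.06 log units; beyond the scatter). Compound 4 is estimated at 4000 nM, with a range from 1500 nM to 15000 nM.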

Compound 4, concentration for 50% growth inhibition: 6000 nM
Beside the measured number, compound 4's estimate is 1.5-fold (0.18 log units) below it; the range from low to high includes it.
By their numbers in this assay, from the lowest: compounds 2 and 1 (each within the scatter of the next); then compound 4; then compound 3.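

The step of a 7.7-fold lower number from compound 3 to compound 4 (0.88 log units; beyond the scatter) in this assay shows that, on a saturated chain carbon, three bonds along the chain from a sulfonamide nitrogen, (2-methoxybenzyl)amino in place of benzyl(methyl)amino closes much of the gap that set compound 3 apart. The return is not complete, however: both a 2.4-fold higher number from compound 2 to compound 4 (0.38 log units; beyond the scatter) and a 2.2-fold higher number from compound 1 to compound 4 (0.35 log units; beyond the scatter) lie beyond the scatter, though only modestly, so 2-methoxyphenyl does not fully match the two ring groups on the chain carbon bound to an amine nitrogen. The exchange also gives the entering group a hydrogen-bond donor that the leaving group lacks, but nothing shown here accounts for the size of any of these steps.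

The exchange removes the methyl from the amine nitrogen and adds the methoxy in one move, so the compounds shown do not separate the two, and a plain benzylamino or a (2-methoxybenzyl)(methyl)amino group at this place would be needed to do so. Going by these compounds, it also remains open whether a methyl on the amine nitrogen would raise the number in the same way with naphthalen-1-yl or 2,3-dihydro-1,4-benzodioxin-2-yl on the chain carbon.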